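Shared-core series: cytotoxicity working notes

A few compounds are considered here, and "the series" means these few. Any claim that something is new, unique, unknown or untested is made for them only; others in the source may bear on it.

compound 1 `CNC(=O)c1cccn1-c1ccc2c(c1)B(O)OC2` — > 10 ug/mL
compound 2 `O=C(c1ccccc1)c1ccn(-c2ccc3c(c2)B(O)OC3)c1` — > 10 ug/mL

In an ADME assay on L929 cells (Mus musculus) for cytotoxicity, read by resazurin assay, with a stated time of 72 h (a lower number here means a stronger inhibitor, a higher number a weaker inhibitor), compound 1 gives > 10 ug/mL, which is a limit of the assay and not a number. In this assay compound 2 gives > 10 ug/mL, again a limit rather than a number. Within the data shown here, compound 2 thus stands at the limit, and so does the only further value shown (the limit of > 10 ug/mL in this assay, at which 2 of the 2 values shown sit), so neither compound can be placed against the other and no order between them is known.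

Compound 3 `CCCC(=O)c1ccn(-c2ccc3c(c2)B(O)OC3)c1` has not yet been measured in this assay. It differs from compound 2 by propyl in place of phenyl on a carbonyl carbon. Among the measured compounds shown here, no step between measured compounds is known that would calibrate this change, so its size cannot be read from the series itself.

With both measured values sitting at the limit, the step expected in this assay is a step that the limit leaves unreadable from compound 2 to compound 3, that is, none beyond the scatter. Compound 3 is therefore estimated at 15 ug/mL, with a range from 7 ug/mL to 40 ug/mL, and it is expected that this assay again reports only a limit for it.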

Compound 3, half-maximal inhibitory concentration: > 10 ug/mL
Compound 3: a limit, no number; the forecaster's own chance of this, stated with the estimate: 80%; the middle value lies beyond the limit too.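

In this assay compound 3 gives > 10 ug/mL, a limit and not a number. Compound 2 also stands at a limit, so no step between compound 2 and compound 3 can be read: the limit of > 10 ug/mL in this assay, at which 3 of the 3 values shown sit.

The compounds shown leave open where the half-maximal inhibitory concentration of each lies, and whether propyl in place of phenyl on a carbonyl carbon shifts it.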